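The source may report more compounds than this note shows. Statements on the series, on what has been measured and on what is new or still open speak of the compounds shown alone.

Measured so far:
- compound 1 `COc1cc(-c2cc(/C=C/C(=O)c3ccc(N)cc3)[nH]n2)cc(OC)c1OC`: 4330 nM
- compound 2 `COc1ccc(-c2cc(/C=C/C(=O)c3ccc(OC)c(OC)c3)[nH]n2)cc1`: 3550 nM
- compound 3 `COc1cc(-c2cc(/C=C/C(=O)c3ccc(Cl)c(Cl)c3)[nH]n2)cc(OC)c1OC`: 43000 nM

These three compounds were tested in a functional assay on A498 cells (Homo sapiens) for inhibition, read by sulforhodamine B assay, with a stated time of 48 h; on this read-out lower numbers stand for stronger inhibition of growth and higher numbers for weaker inhibition of growth. Compound 3 stands at the highest number of the three, that is, it inhibits growth least: compound 1 gives a number a 9.9-fold higher number from compound 1 to compound 3 (1.00 log units; beyond the scatter) away, and compound 2 sits even further below it.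

Compound 4 `COc1ccc(C(=O)/C=C/c2cc(-c3cc(OC)c(OC)c(OC)c3)n[nH]2)cc1` is the next compound and has not yet been measured in this assay. It differs from compound 3 in one place: 4-methoxyphenyl in place of 3,4-dichlorophenyl on a carbonyl carbon.

Among the compounds with values here, one measured step bears directly on this change. The step of a 9.9-fold higher number from compound 1 to compound 3 (1.00 log units; beyond the scatter) shows that the group on this carbonyl carbon matters a great deal, and that 3,4-dichlorophenyl gives the weakest growth inhibition seen here. Compound 2, which carries a methoxy-bearing ring on the same carbonyl carbon, gives 3550 nM. Replacing 3,4-dichlorophenyl by 4-methoxyphenyl is therefore expected to bring the number back down, most likely toward the range of compounds 1 and 2, so a step of an 8.6-fold lower number from compound 3 to compound 4 (0.93 log units; beyond the scatter) is expected. Compound 4 is estimated at 5000 nM, with a likely range from 2000 nM to 15000 nM.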

Compound 4, concentration for total growth inhibition: 3940 nM
The estimate for compound 4 lay 1.3-fold (0.10 log units) above the measured number, within the range that was stated.
By their numbers in this assay, from the lowest: compounds 2, 4 and 1 (each within the scatter of the next); then compound 3.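

Putting 4-methoxyphenyl in place of 3,4-dichlorophenyl on the carbonyl carbon gives a large step (an 11-fold lower number from compound 3 to compound 4 (1.04 log units; beyond the scatter)), so with the rest of the molecule unchanged, this one group separates weak growth inhibition from a number in the range of compound 1. Methoxy in place of amino on the aromatic carbon gives (a 1.1-fold lower number from compound 1 to compound 4 (0.04 log units; within the scatter)), so these two groups cannot be told apart on this read-out, and the 3,4-dichlorophenyl ring of compound 3 remains the only outlier among the compounds compared here. No evidence is available to explain why this ring change has so large an effect.

Still open, on these data alone, is how a phenyl ring carrying a single chlorine or a carboxylic acid would compare. Also open, as far as these compounds go, is whether a non-aromatic group such as cyclohexyl on this carbonyl carbon would keep the number in the range of compound 4.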